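The compounds below may be only part of what the source reports. "The series", "measured", "known", "first", "only" and "open" are said of these compounds alone.

Measured in a functional assay on HepG2 cells (Homo sapiens) for antiproliferative activity, read by MTT assay, with a stated time of 72 h; a lower number here means a stronger inhibitor, a higher number a weaker inhibitor:
- compound 1 `COc1ncc(-c2ccc3c(c2)N(C2CCCCC2)C(=O)CO3)cc1NS(=O)(=O)c1ccc(F)cc1`: > 40000 nM
- compound 2 `CC(C)N1C(=O)COc2ccc(-c3cnc(Cl)c(NS(=O)(=O)c4ccc(F)cc4)c3)cc21`: 21500 nM

Compound 1 reads > 40000 nM, which is a limit of the assay and not a number.

Within the data shown here, compound 2 gives 21500 nM, the only actual number so far, so it has no numerical neighbour to be ranked against.

The next compound is compound 3 `COc1ncc(-c2ccc3c(c2)N(C(C)C)C(=O)CO3)cc1NS(=O)(=O)c1ccc(F)cc1`, which is not yet measured. It keeps the rest of compound 2 and has methoxy in place of chloro on an aromatic carbon. This carbon belongs to a six-membered aromatic ring with 1 nitrogen and lies next to the ring nitrogen, ortho to a large group and para to a large group.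

Among the measured compounds shown here, no measured pair isolates this exchange, so its size cannot be read from the data. The working expectation in this assay is therefore a step no larger than the scatter, in neither direction, anchored on compound 2 at 21500 nM.

The expected change is a 1.2-fold lower number from compound 2 to compound 3 (0.08 log units; within the scatter).

For compound 3 the estimated value is 18000 nM, with an expected range of 6000 nM to 40000 nM.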

Compound 3, half-maximal inhibitory concentration: 37200 nM
For compound 3 the middle estimate is 2.1-fold (0.32 log units) below the measured one; the measured number falls inside the stated range.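

In this assay, among these compounds, methoxy in place of chloro on an aromatic carbon next to the ring nitrogen gives a 1.7-fold higher number from compound 2 to compound 3 (0.24 log units; within the scatter), the first reading of this exchange, and it shows that the two groups cannot be told apart at this position in this assay. Isopropyl in place of cyclohexyl on the amide-type nitrogen gives an at least 1.0-fold lower number from compound 1 to compound 3 (0.03 log units; that floor lies within the scatter), which fixes only a floor for that exchange. The value of compound 1 is a limit and not a number, so the true size of that step cannot be read: the limit of > 40000 nM in this assay, at which 1 of the 3 values shown sits.

Chloro and methoxy alone do not tell whether this carbon can carry a step beyond the scatter in this assay, and an amine or a carboxylic acid at the same place would test that. Among the compounds shown here, on the amide-type nitrogen, a longer chain such as n-butyl would show whether the group there matters, since the only pair at that nitrogen ends in a limit.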